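Aryl ether to aryl thioether on the shared core

The source may report more compounds than this note shows. Statements on the series, on what has been measured and on what is new or still open speak of the compounds shown alone.

Going by the values given here, in a functional assay on HOP-62 cells (Homo sapiens) for inhibition, read by sulforhodamine B assay, with a stated time of 48 h (a higher number here means a weaker inhibitor of growth, a lower number a stronger inhibitor of growth), compound 1 `Nc1cc(N)c2nc(-c3ccccc3)c(Oc3ccc(Cl)c(Cl)c3)nc2c1` gives 17000 nM, and this is the only number in the set. Compound 2 `CCOC(=O)[C@H](CCC(=O)O)NC(=O)c1ccc(CNc2nc3cc(N)cc(N)c3nc2-c2ccccc2)cc1` in this assay reports only a limit, < 100000 nM, which is where the limit of < 100000 nM in this assay, at which 1 of the 2 values shown sits, places its result. Among the compounds with values here, no pair of measured compounds differing in one place is available, so the size of a single change in this assay cannot be read from the data themselves. Compound 3 `COc1ccc(Sc2nc3cc(N)cc(N)c3nc2-c2ccccc2)cc1` differs from compound 1 by (4-methoxyphenyl)sulfanyl in place of 3,4-dichlorophenoxy on an aromatic carbon. Without a measured step to lean on, the change is expected to leave growth inhibition in this assay at a similar level, and the expected step is a 1.2-fold higher number from compound 1 to compound 3 (0.07 log units; within the scatter), within or only modestly beyond the usual scatter. Compound 3 is estimated at 20000 nM, with a plausible range from 5000 nM to 80000 nM, and a real chance that only a limit is returned.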

Compound 3, concentration for 50% growth inhibition: < 100000 nM
Compound 3: a limit, no number; the forecaster's own chance of this, stated with the estimate: 20%; the middle value is on the limit's open side.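

In this assay, going by these compounds alone, compound 3 returns only a limit, < 100000 nM, so no step from compound 1 to compound 3 can be read. Still open, on these data alone, is whether (4-methoxyphenyl)sulfanyl in place of 3,4-dichlorophenoxy on the shared core changes growth inhibition at all, and in which direction.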